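Furan to Thiophene on a Cytotoxicity Read-out

This account rests on a few compounds, and the source may have more. Where it says the series, first, only, none or still open, it means among the compounds named here.

Compound 1, `O=c1[nH]cnc2c1c(-c1ccoc1)cn2[C@@H]1O[C@H](CO)[C@@H](O)[C@H]1O`, was examined in an ADME assay on MRC5 cells (Homo sapiens), read by MTT assay, with a stated time of 72 h; on this read-out higher numbers stand for weaker inhibition and lower numbers for stronger inhibition. In this assay compound 1 returned only a limit of the assay, > 100000 nM. Compound 2, `CSc1ncnc2c1c(-c1ccccc1)cn2[C@@H]1O[C@H](CO)[C@@H](O)[C@H]1O`, was examined in the same way. In this assay compound 2 also returned only a limit of the assay, > 100000 nM. Going by the values given here, compound 1 therefore stands at the same limit as the one other value shown, (the limit of > 100000 nM in this assay, at which 2 of the 2 values shown sit); no measured step between compounds that differ in a single place is available, and no spread among the values can be seen.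

Compound 3, `O=c1[nH]cnc2c1c(-c1ccsc1)cn2[C@@H]1O[C@H](CO)[C@@H](O)[C@H]1O`, has not yet been measured in this assay. It differs from compound 1 in one place: thiophen-3-yl in place of furan-3-yl on an aromatic carbon. Because compound 1 sits at the limit > 100000 nM, the step that the limit leaves unreadable from compound 1 to compound 3 is expected to be none beyond the scatter, in either direction. Compound 3 is accordingly estimated at 150000 nM, within a range from 60000 nM to 500000 nM, and the expectation is that the assay will once more report only a limit rather than a number.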

Compound 3, half-maximal inhibitory concentration: > 100000 nM
Compound 3 was reported as a limit (the forecaster's own chance of this, stated with the estimate: 85%); the middle value is on the limit's open side.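

In this assay compound 3 gave only a limit, as did compound 1, so no step between compound 1 and compound 3 can be read: the limit of > 100000 nM in this assay, at which 3 of the 3 values shown sit.

The compounds shown leave open whether any change to the shared core would give a number rather than a limit in this assay.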